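This account rests on a few compounds, and the source may have more. Where it says the series, first, only, none or still open, it means among the compounds named here.

Of the compounds shown here, two from this series have been measured so far. Compound 1, `C#CCSc1nc(Nc2cccc(Cl)c2)c(C#N)c(-c2ccccc2)n1`, gives 10500 nM in a functional assay on B16-F10 cells (Mus musculus) for inhibition, read by MTT assay, with a stated time of 72 h; on this read-out higher numbers stand for weaker inhibition and lower numbers for stronger inhibition. Compound 2, `COc1ccccc1Nc1nc(SCc2cn(Cc3ccccc3Cl)nn2)nc(-c2ccccc2)c1C#N`, gives 7860 nM in this assay. Compound 2 and compound 1 thus sit close together: the gap between their two numbers lies within the usual scatter of repeated measurements, so the two cannot be told apart on the data shown.

The next compound is compound 3, `Cc1ccccc1Nc1nc(SCc2cn(Cc3ccccc3Cl)nn2)nc(-c2ccccc2)c1C#N`. It differs from compound 2 in one place: methyl in place of methoxy on an aromatic carbon. Methyl in place of methoxy on an aromatic carbon is a small change, and no measured pair in this set shows what such a change does here.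

Without a measured step to lean on, the expectation for compound 3 is simply that it stays close to compound 2, with an estimated step of a 1.1-fold higher number from compound 2 to compound 3 (0.03 log units; within the scatter) in this assay, which is none beyond the scatter. Compound 3 is therefore expected to give about 8500 nM, with a range from 3500 nM to 20000 nM.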

Compound 3, half-maximal inhibitory concentration: 2760 nM
Estimate against measurement, compound 3: 3.1-fold (0.49 log units) above, and the stated range ends above it.
By their numbers in this assay, from the lowest: compound 3; then compounds 2 and 1 (each within the scatter of the next).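

Among the compounds shown here, replacing methoxy with methyl on this ring gives the first step that can be read as a real difference, a 2.8-fold lower number from compound 2 to compound 3 (0.45 log units; beyond the scatter) in this assay. The earlier compounds shown here could not show this, as compound 1 and compound 2 differ in more than one place and their numbers lie within the scatter; this pair shows that a small edit on an aromatic carbon, ortho to a large group, can move the number beyond the scatter. Nothing shown here bears on the reason for this step.

From the compounds shown here alone, it remains open whether the lower number reflects the arrival of methyl or the departure of methoxy, and a hydrogen, a chlorine atom, an ethyl group or a hydroxyl group at the same place would help separate these two readings. Going by these compounds, it also remains open whether the same swap would give a similar step elsewhere, as this is a single pair of compounds measured in one assay.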